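Benzothiazolyl amide in the trifluoromethyl gem-diol series

A few compounds are considered here, and "the series" means these few. Any claim that something is new, unique, unknown or untested is made for them only; others in the source may bear on it.

Measured compounds:
compound 1 `O=C(CCCCCCNC(=O)C(O)(O)C(F)(F)F)Nc1ccc(Br)cc1`, 11000 nM
compound 2 `O=C(CCCCCCNC(=O)C(O)(O)C(F)(F)F)Nc1ccc(Cl)cc1`, 52000 nM

In an assay on isolated protein for inhibition of histone deacetylase 8 (Homo sapiens), read by chemiluminescence, with a stated time of 3 h (a lower number here means a stronger inhibitor, a higher number a weaker inhibitor), compound 1 gives 11000 nM, and compound 2 gives 52000 nM, the highest number of the two; the step of a 4.7-fold higher number from compound 1 to compound 2 (0.67 log units; beyond the scatter) separates them. Compound 3 `O=C(CCCCCCNC(=O)C(O)(O)C(F)(F)F)Nc1nc2ccccc2s1` differs from compound 2 by 1,3-benzothiazol-2-yl in place of 4-chlorophenyl on an amide-type nitrogen. For the measured compounds named here, the only measured step concerns a halogen swap on the aromatic ring and does not speak to an aromatic ring exchange of this kind, so no step beyond the scatter is firmly expected in this assay in either direction. Compound 3 is therefore estimated at 25000 nM, with a broad range from 5000 nM to 120000 nM, meaning an expected step of a 2.1-fold lower number from compound 2 to compound 3 (0.32 log units; beyond the scatter).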

Compound 3, half-maximal inhibitory concentration: 5300 nM
For compound 3 the middle estimate is 4.7-fold (0.67 log units) above the measured one; the measured number falls inside the stated range.
By their numbers in this assay, from the lowest: compound 3; then compound 1; then compound 2.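

Placing 1,3-benzothiazol-2-yl on the amide-type nitrogen gives a 9.8-fold lower number from compound 2 to compound 3 (0.99 log units; beyond the scatter) in this assay and, against the bromo analogue, a 2.1-fold lower number from compound 1 to compound 3 (0.32 log units; beyond the scatter) on the same scale. This makes compound 3 the strongest inhibitor of the three, so this position accepts more than a halogen swap on a phenyl ring, and the entering group brings a second ring and two hydrogen-bond acceptors. Nothing available explains this gain. The compounds shown leave open whether the ring sulfur or ring nitrogen matters, which a benzoxazol-2-yl or quinolin-2-yl group could address. They also leave open whether a longer chain would keep the gain seen with compound 3.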